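Hydrazone aryl swap on the acylurea-thiazole series

A few compounds are considered here, and "the series" means these few. Any claim that something is new, unique, unknown or untested is made for them only; others in the source may bear on it.

Measured so far:
compound 1 `Cc1nc(N(C)C(=O)NC(=O)c2c(F)cccc2F)sc1C(=O)N/N=C/c1ccc(F)cc1` — > 100 ug/mL
compound 2 `CN(C(=O)NC(=O)c1c(F)cccc1F)c1nc(C(F)(F)F)c(C(=O)N/N=C/c2cc(C(F)(F)F)cc(C(F)(F)F)c2)s1` — 6.28 ug/mL

In a functional assay on HepG2 cells (Homo sapiens) for inhibition, read by MTT assay, with a stated time of 72 h (a lower number here means a stronger inhibitor, a higher number a weaker inhibitor), compound 1 gives only a limit, > 100 ug/mL, not a number; this is the limit of > 100 ug/mL in this assay, at which 1 of the 2 values shown sits. Compound 2 gives 6.28 ug/mL in this assay. Among the compounds with values here, no step between measured compounds is available, since the two differ in more than one place; their values show only that one sits at the limit and the other gives a number.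

Compound 3 `COc1cc(/C=N/NC(=O)c2sc(N(C)C(=O)NC(=O)c3c(F)cccc3F)nc2C)cc(OC)c1OC` is not yet measured. It differs from compound 1 by 3,4,5-trimethoxyphenyl in place of 4-fluorophenyl on a carbon with a double bond to nitrogen. Because compound 1 sits at the limit (the limit of > 100 ug/mL in this assay, at which 1 of the 2 values shown sits), any step in this assay can only be towards a stronger number or none beyond the scatter. The step of an at least 1.6-fold lower number from compound 1 to compound 3 (0.22 log units; that floor lies within the scatter) is expected to be modest and uncertain. Compound 3 is expected to give about 60 ug/mL in this assay, with a range from 15 ug/mL to 200 ug/mL.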

Compound 3, half-maximal inhibitory concentration: > 100 ug/mL
Compound 3: a limit, no number (the forecaster's own chance of this, stated with the estimate: 40%); at least 1.6-fold (0.22 log units) between middle value and limit.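

In this assay compound 3 gives > 100 ug/mL as a limit and not a number. Compound 1 also gives only a limit, so no step can be read between compound 1 and compound 3: the limit of > 100 ug/mL in this assay, at which 2 of the 3 values shown sit. The compounds shown leave open whether this aryl swap alone changes activity.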